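The source may hold more compounds than are shown below. What is called first, only, known or untested is meant among the compounds shown, and "the series" means these compounds.

Working notes on the series. For the measured compounds named here, in an ADME assay on Vero cells (Chlorocebus sabaeus) for cytotoxicity, read by CellTiter-Glo and ATP content, with a stated time of 72 h (on this read-out lower numbers stand for higher toxicity in this test and higher numbers for lower toxicity in this test), compound 1 (`Nc1c(C2=NCCN2)cnn1-c1ccc(Cl)c(Cl)c1`) gives 244000 nM, the only true number so far. Compound 2 (`Nc1c(C2=NCCCN2)cnn1-c1cccc(Cl)c1`) is reported as > 500000 nM, which is a limit of the assay and not a number. The data in hand record this as the limit of > 500000 nM in this assay, at which 1 of the 2 values shown sits. Compound 2 therefore has no exact place on the scale.

Compound 3 (`Nc1c(C2=NCCCN2)cnn1-c1ccc(Cl)c(Cl)c1`) follows from compound 2 by a single change: chloro in place of hydrogen on an aromatic carbon. This puts chloro in place of hydrogen on an aromatic carbon, ortho to a chloro group and para to a large group.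

Going by the values given here, no measured step isolates this change, so its size in this assay cannot be read from the data. A modest move towards lower numbers, meaning higher toxicity in this test, is expected rather than none. Among the compounds with values here, that expectation leans on compound 1 at 244000 nM, the one measured number available. The expected change is an at least 1.9-fold lower number from compound 2 to compound 3 (0.28 log units; that floor lies within the scatter). For compound 3 the estimated value is 260000 nM, with an expected range from 110000 nM to 500000 nM.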

Compound 3, half-maximal cytotoxic concentration: > 500000 nM
Compound 3 was reported as a limit; the forecaster's own chance of this, stated with the estimate: 25%; middle value at least 1.9-fold (0.28 log units) from the limit.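

In this assay compound 3 gives > 500000 nM, a limit of the assay and not a number. The step made by chloro in place of hydrogen on an aromatic carbon, ortho to a chloro group and para to a large group, cannot be read, but this change does not bring the series off the limit when the six-membered non-aromatic ring is present: the limit of > 500000 nM in this assay, at which 2 of the 3 values shown sit.

For the compounds shown here, the one readable step is the exchange of the five-membered non-aromatic ring for the six-membered one, on an aromatic carbon, with an at least 2.0-fold higher number from compound 1 to compound 3 (0.31 log units; beyond the scatter), so the same chloro pattern on the aromatic ring does not by itself give a measured number in this pair.

Still open, on these data alone, is whether a methoxy group or a carboxylic acid at this aromatic carbon would bring the six-membered ring compounds to a true number. Also open, as far as these compounds go, is how the five-membered ring compound responds to chloro in place of hydrogen at this position, so the size of this change on a true number remains unknown.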